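The compounds below may be only part of what the source reports. "The series", "measured", "known", "first", "only" and "open" are said of these compounds alone.

Measured compounds:
compound 1 `CC1=C(N2CC2)C(=O)C(CC(C)OC(N)=O)=C(N2CC2)C1=O` — 6.14
compound 2 `CC1=C(N2CC2)C(=O)C(C(C)C)=C(N2CC2)C1=O` — 5.6
compound 3 `CC1=C(N2CC2)C(=O)C(C2CCCCC2)=C(N2CC2)C1=O` — 5.82

All three numbers come from a functional assay on L1210 cells (Mus musculus), with a stated time of 12 days; a lower number here means a less potent compound, a higher number a more potent compound, by a factor of ten per unit of this negative logarithm. Compound 3 stands second highest of the three; its nearest neighbour is compound 2, and the difference a number 0.22 log units higher from compound 2 to compound 3 (within the scatter) lies within the scatter, so no order between the two is claimed. Its furthest neighbour is compound 1, from which a number 0.32 log units lower from compound 1 to compound 3 (beyond the scatter) is beyond the scatter. The other measured step, a number 0.54 log units lower from compound 1 to compound 2 (beyond the scatter), is also beyond the scatter.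

Compound 4 `COC(CO)C1=C(N2CC2)C(=O)C(C)=C(N2CC2)C1=O` has not yet been measured. The change from compound 3 is 2-hydroxy-1-methoxyethyl in place of cyclohexyl on a double-bonded ring carbon. For the measured compounds named here, the measured step that bears most directly on it is the one from compound 1 to compound 3, where a group carrying oxygen and nitrogen gave way to cyclohexyl and the number fell by a number 0.32 log units lower from compound 1 to compound 3 (beyond the scatter). Compound 4 reverses the direction of that exchange, bringing back a side chain with oxygen, so compound 4 is expected to recover some of that ground. The step to compound 4 is estimated at a number 0.18 log units higher from compound 3 to compound 4 (within the scatter), a rise that may not exceed the scatter. Compound 4 is therefore expected to give 6, within a range from 5.5 to 6.5.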

Compound 4, logarithm of the reciprocal of the active concentration, log(1/C): 6.9
The estimate for compound 4 lay 0.90 log units below the measured number, outside the stated range (above it).
By their numbers in this assay, from the lowest: compounds 2 and 3 (each within the scatter of the next); then compound 1; then compound 4.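

For the compounds shown here, on this double-bonded ring carbon, 2-hydroxy-1-methoxyethyl proves far better than either carbon-only group in this assay, with a number 1.08 log units higher from compound 3 to compound 4 (beyond the scatter) and a number 1.30 log units higher from compound 2 to compound 4 (beyond the scatter), steps much larger than any seen among the earlier compounds. It also exceeds the side chain of compound 1, which carries oxygen and nitrogen, with a number 0.76 log units higher from compound 1 to compound 4 (beyond the scatter), so the presence of oxygen in the side chain does not by itself fix the level reached at this position, although both oxygen-bearing groups stand above both carbon-only groups and none of the four compounds goes against that order. No measurement offered here accounts for the size of these steps.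

The compounds shown leave open whether the hydroxyl or the methoxy of the side chain carries the step, as a 2-hydroxyethyl or a 2-methoxyethyl group at the same carbon would help to separate them. They also leave open whether the branch matters and whether an amine or a carboxylic acid at the end of such a chain would hold the number in this assay.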